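Cytotoxicity notes on a bicyclic amine series with thiophene methyl

The compounds below may be only part of what the source reports. "The series", "measured", "known", "first", "only" and "open" are said of these compounds alone.

Measured so far in an ADME assay on MDCK cells (Canis lupus familiaris) for cytotoxicity, read by microscopy, with a stated time of 48 h; on this read-out higher numbers stand for lower toxicity in this test and lower numbers for higher toxicity in this test:
- compound 1 `C=C(C)c1csc(CN[C@@H]2C[C@H]3C[C@@H]([C@H]2C)C3(C)C)c1` gives 25000 nM
- compound 2 `C[C@H]1[C@H](NCc2sccc2-c2ccccc2)C[C@H]2C[C@@H]1C2(C)C` gives 12500 nM

Compound 1 stands highest of the two numbers; its nearest neighbour, compound 2, shows a number whose gap from that of compound 1 lies within the scatter, so no order between the two is claimed.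

Compound 3 `Cc1csc(CN[C@@H]2C[C@H]3C[C@@H]([C@H]2C)C3(C)C)c1` remains to be measured in this assay. It differs from compound 1 by methyl in place of 1-methylethenyl on an aromatic carbon. Among the measured compounds shown here, no step between measured compounds informs this change, so a step of no change at the digits printed from compound 1 to compound 3 (within the scatter) is expected to stay within the scatter, in no firm direction. For compound 3 the estimate is 25000 nM, with a range from 12500 nM to 50000 nM.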

Compound 3, minimum cytotoxic concentration: 12500 nM
For compound 3 the middle estimate is 2.0-fold (0.30 log units) above the measured one; the range from low to high includes it.
By their numbers in this assay, from the lowest: compounds 2, 3 and 1 (each within the scatter of the next).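

In this assay the swap to methyl from 1-methylethenyl on this aromatic carbon gives a 2.0-fold lower number from compound 1 to compound 3 (0.30 log units; within the scatter) as the first step read at this position. On this step, removing the double bond outside aromatic rings and shortening the group leaves the number of the core of compound 1 within the scatter. No supporting measurement bears on the reason for this result.

From the compounds shown here alone, whether a different group on this carbon, such as an amine or a carboxylic acid, would shift the number beyond the scatter remains open. One step also sets no trend for this position.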